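The source may hold more compounds than are shown below. What is called first, only, known or untested is meant among the compounds shown, and "the series" means these compounds.

Measured compounds:
- compound 1 `Fc1ccccc1NC(=S)Nc1cccc(C(F)(F)F)c1`, in an ADME assay on BHK cells (Mesocricetus auratus) for cytotoxicity, read by MTT assay, with a stated time of 96 h (on this read-out higher numbers stand for lower toxicity in this test and lower numbers for higher toxicity in this test), compound 1 gives 54000 nM
- compound 2 `CCCCc1ccc(NC(=S)Nc2cccc(C(F)(F)F)c2)c(C)c1`, in this assay compound 2 gives 9000 nM

Compound 1 stands at the highest of the two numbers in this assay; compound 2 sits at the lower number, and the gap between the two lies beyond the scatter of repeated measurements. No single-point comparison between the measured compounds exists, as the two differ in more than one place.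

The unmeasured compound 3 `FC(F)(F)c1cccc(NC(=S)Nc2ccc(I)cc2)c1` departs from compound 1 in one place: 4-iodophenyl in place of 2-fluorophenyl on an amide-type nitrogen. Within the data shown here, no measured pair shows what this exchange does in this assay, so the direction and size of the step are open. The series offers only that a more heavily substituted aryl group on the thiourea, in compound 2, goes with a lower number than compound 1.

On that thin footing, the step from compound 1 to compound 3 is expected to be modest and downward, a 2.2-fold lower number from compound 1 to compound 3 (0.33 log units; beyond the scatter), though a step of no size beyond the scatter remains possible. For compound 3 the estimate in this assay is 25000 nM, with a range from 8000 nM to 75000 nM.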

Compound 3, half-maximal cytotoxic concentration: 9400 nM
The estimate for compound 3 lay 2.7-fold (0.42 log units) above the measured number; measured number inside the range.
By their numbers in this assay, from the lowest: compounds 2 and 3 (each within the scatter of the next); then compound 1.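

In this assay, the aryl group on the amide-type nitrogen whose other neighbour is the thiocarbonyl carbon proves to be a position that affects the read-out: 4-iodophenyl in place of 2-fluorophenyl gives a 5.7-fold lower number from compound 1 to compound 3 (0.76 log units; beyond the scatter), which points to higher toxicity in this test. Among these compounds, this is the first reading of a change at one place, and it shows that the number can move even when the entering and leaving groups match in heavy-atom count, ring type, hydrogen-bond donors and acceptors, and net charge. No measurement at hand bears on why this exchange lowers the number.

The exchange replaces the halogen and also alters its place on the ring, so this single step cannot separate the two changes, and a version of the core of compound 1 carrying fluorine or iodine at the other of these two ring places would be needed to do so. Also open, going by these compounds, is how an unsubstituted phenyl group, or a phenyl group bearing a methoxy group or a carboxylic acid, would behave at this position.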